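A few compounds are considered here, and "the series" means these few. Any claim that something is new, unique, unknown or untested is made for them only; others in the source may bear on it.

Series notes. The shared core carries a nitrile and two phenyl groups on every member; the compounds differ only in the side chain at the remaining position. In an assay for inhibition of Polyunsaturated fatty acid lipoxygenase ALOX15 (Oryctolagus cuniculus) (a lower number here means a stronger inhibitor, a higher number a weaker inhibitor), compound 1 `COc1ccccc1COc1c(-c2ccccc2)c(-c2ccccc2)n2ccc(C#N)cc12` gives "not determined" (no result reported), and compound 2 `N#Cc1ccn2c(-c3ccccc3)c(-c3ccccc3)c(C(O)C3CCCCC3)c2c1` gives "not determined" (no result reported), so neither of these two has a result recorded. Among the measured compounds shown here, compound 3 `N#Cc1ccn2c(-c3ccccc3)c(-c3ccccc3)c(Cc3ccccc3)c2c1` is the single member with a number: in this assay compound 3 gives 46000 nM, a weak inhibitor and, with the other two entries blank, the only point of reference the set offers.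

Compound 4 `N#Cc1ccn2c(-c3ccccc3)c(-c3ccccc3)c(C(O)c3ccccc3)c2c1` is the next member to be measured in this assay. Against compound 3 the change is hydroxy in place of hydrogen on a saturated chain carbon bound to two aromatic carbons. For the measured compounds named here, no pair of measured compounds shows what such a change does here, so nothing supports a direction for the step. The step of a 1.2-fold lower number from compound 3 to compound 4 (0.06 log units; within the scatter) that the estimate below means is expected to lie within the usual scatter. For compound 4 the expected value in this assay is estimated at 40000 nM, with a range from 15000 nM to 120000 nM.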

Compound 4, half-maximal inhibitory concentration: 48000 nM
Beside the measured number, compound 4's estimate is 1.2-fold (0.08 log units) below it, and the stated range covers the measured number.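

In this assay, among the compounds shown here, hydroxy in place of hydrogen on a saturated chain carbon bound to two aromatic carbons gives a 1.0-fold higher number from compound 3 to compound 4 (0.02 log units; within the scatter), the first readable step. At this position, benzyl and hydroxy(phenyl)methyl therefore cannot be told apart in this assay, and a hydrogen-bond donor and acceptor can be added to the side chain with no change beyond the scatter, leaving both compounds weak inhibitors. No available evidence accounts for this result.

Compound 2 gives "not determined" (no result reported), so whether hydroxy behaves the same way with a saturated ring on that carbon cannot be read. Also open, as far as these compounds go, is whether an amine or a carboxylic acid on that chain carbon, or a longer chain in place of benzyl, would move the number beyond the scatter.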